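Changing the Aryl Group on the Amine Nitrogen

A few compounds are considered here, and "the series" means these few. Any claim that something is new, unique, unknown or untested is made for them only; others in the source may bear on it.

Measured in a functional assay on MCF7 cells (Homo sapiens) for inhibition; on this read-out lower numbers stand for stronger inhibition and higher numbers for weaker inhibition:
Compound 1, `CCn1c(=O)/c(=C2\Sc3ccccc3N2C)s/c1=C\c1ccncc1Nc1cc(C)ccc1C`, gives 1700 nM.
Compound 2, `CCn1c(=O)/c(=C2\Sc3ccccc3N2C)s/c1=C\c1ccncc1Nc1ccccc1Cl`, gives 750 nM.

Among the measured compounds shown here, of these two numbers, compound 2 has the lower one, and the only measured step, a 2.3-fold lower number from compound 1 to compound 2 (0.36 log units; beyond the scatter), also changed the group on this same nitrogen. Compound 3, `CCn1c(=O)/c(=C2\Sc3ccccc3N2C)s/c1=C\c1ccncc1Nc1cc(F)ccc1F`, differs from compound 2 by 2,5-difluorophenyl in place of 2-chlorophenyl on a nitrogen on an aromatic ring. Because a 2.3-fold lower number from compound 1 to compound 2 (0.36 log units; beyond the scatter) was only modest, compound 3 is expected to stay close to compound 2, with a step of a 1.2-fold higher number from compound 2 to compound 3 (0.08 log units; within the scatter) that need not exceed the scatter. Compound 3 is therefore estimated at 900 nM, within a range from 350 nM to 2300 nM.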

Compound 3, half-maximal inhibitory concentration: 1500 nM
For compound 3 the middle estimate is 1.7-fold (0.22 log units) below the measured one; the range from low to high includes it.
By their numbers in this assay, from the lowest: compounds 2, 3 and 1 (each within the scatter of the next, the first and the last beyond it).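

Replacing 2-chlorophenyl with 2,5-difluorophenyl on this nitrogen gives one step (a 2.0-fold higher number from compound 2 to compound 3 (0.30 log units; within the scatter)), and replacing 2,5-dimethylphenyl with 2,5-difluorophenyl gives another (a 1.1-fold lower number from compound 1 to compound 3 (0.05 log units; within the scatter)). Compound 3 therefore cannot be told apart from either neighbour, although compound 1 and compound 2 lie beyond the scatter of each other. No measured evidence here accounts for these numbers. Open, going by these compounds, is how this number would respond to a phenyl ring carrying an amine or a carboxylic acid, or to a plain ethyl chain on this nitrogen.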